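The source may report more compounds than this note shows. Statements on the series, on what has been measured and on what is new or still open speak of the compounds shown alone.

In a functional assay on SK-OV-3 cells (Homo sapiens) for antiproliferative activity, read by MTT assay, with a stated time of 72 h (on this read-out higher numbers stand for weaker inhibition and lower numbers for stronger inhibition), compound 1 `O=C(CCc1cccc2c1B(O)OC2)Nc1ccc(I)cc1`, with iodo on the aromatic carbon, gives 51000 nM, and compound 2 `C#Cc1ccc(NC(=O)CCc2cccc3c2B(O)OC3)cc1`, with ethynyl there, gives 6300 nM. Compound 3 `CC(C)(C)OC(=O)Nc1ccc(NC(=O)CCc2cccc3c2B(O)OC3)cc1` gives > 100000 nM, which is a limit of the assay and not a number. Compound 4 `CC(C)(C)OC(=O)NCc1ccc(NC(=O)CCc2cccc3c2B(O)OC3)cc1` differs from compound 3 in one place, with ((tert-butoxycarbonyl)amino)methyl in place of (tert-butoxycarbonyl)amino on an aromatic carbon, para to a large group (((tert-butoxycarbonyl)amino)methyl in place of (tert-butoxycarbonyl)amino on an aromatic carbon). Within the data shown here, no measured step covers this exact change. The nearest evidence is an at least 15-fold higher number from compound 2 to compound 3 (1.20 log units; beyond the scatter), a large step, and an at least 1.9-fold higher number from compound 1 to compound 3 (0.29 log units; that floor lies within the scatter), whose floor lies within the scatter, while an 8.1-fold lower number from compound 1 to compound 2 (0.91 log units; beyond the scatter) is modest. Both steps into compound 3 introduce the group that compound 4 retains in extended form, so weak inhibition is expected to persist in this assay. The expected change is an at least 1.2-fold lower number from compound 3 to compound 4 (0.09 log units; that floor lies within the scatter), and no step beyond the scatter is anticipated. Compound 4 is estimated at 80000 nM, with an expected range of 25000 nM to 130000 nM.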

Compound 4, half-maximal inhibitory concentration: 2000 nM
Compound 4: middle estimate off by 40-fold (1.60 log units), on the high side; the measured number lies below the stated range.
By their numbers in this assay, from the lowest: compound 4; then compound 2; then compound 1. At a limit, above all of these: compound 3.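

In this assay, moving from (tert-butoxycarbonyl)amino to ((tert-butoxycarbonyl)amino)methyl on this aromatic carbon gives an at least 50-fold lower number from compound 3 to compound 4 (1.69 log units; beyond the scatter), so the earlier drop in activity with compound 3 does not extend to every tert-butoxycarbonyl-bearing group at this position. The same group also outperforms the two smaller substituents, with a 3.2-fold lower number from compound 2 to compound 4 (0.50 log units; beyond the scatter) against ethynyl and a 26-fold lower number from compound 1 to compound 4 (1.41 log units; beyond the scatter) against iodo, which makes compound 4 the most potent of the four. The size of the step from compound 3 remains a floor, since that compound stands at a limit of the assay and not at a number: the limit of > 100000 nM in this assay, at which 1 of the 4 values shown sits.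

From the compounds shown here alone, whether a free aminomethyl group or a longer chain, such as aminoethyl, would hold this level of activity remains open. Going by these compounds, it is also open whether the tert-butoxycarbonyl group itself is needed at this position.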